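From Phenyl to 3-Fluorophenyl in Compound 2

This account rests on a few compounds, and the source may have more. Where it says the series, first, only, none or still open, it means among the compounds named here.

In a functional assay on SK-OV-3 cells (Homo sapiens) for antiproliferative activity, read by MTT assay, with a stated time of 72 h (a lower number here means a stronger inhibitor, a higher number a weaker inhibitor), compound 1 `O=C(CCc1cccc2c1B(O)OC2)Nc1ccccc1` gives 200 nM and compound 2 `O=C(CCc1cccc2c1B(O)OC2)Nc1cccc(-c2ccccc2)c1` gives 250 nM. These two numbers lie within the scatter of each other, so compound 2 cannot be separated from compound 1 on the data at hand. Compound 3 `O=C(CCc1cccc2c1B(O)OC2)Nc1cccc(-c2cccc(F)c2)c1` has not yet been measured. It differs from compound 2 in one place, phenyl to 3-fluorophenyl: fluoro in place of hydrogen on an aromatic carbon. The fluoro sits on a six-membered aromatic ring of carbon only, meta to a large group. Within the data shown here, no measured compound carries a fluoro, so the only evidence is indirect. Among the measured compounds shown here, the one measured step is a 1.3-fold higher number from compound 1 to compound 2 (0.10 log units; within the scatter), and it came from phenyl in place of hydrogen on an aromatic carbon. For the measured compounds named here, with that step as the only guide, no shift beyond the scatter is expected in this assay, in either direction. The expected step is a 1.1-fold lower number from compound 2 to compound 3 (0.04 log units; within the scatter). For compound 3 the estimated value is 230 nM, with an expected range from 115 nM to 460 nM.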

Compound 3, half-maximal inhibitory concentration: 480 nM
Beside the measured number, compound 3's estimate is 2.1-fold (0.32 log units) below it; measured number outside the range, above it.
By their numbers in this assay, from the lowest: compounds 1, 2 and 3 (each within the scatter of the next, the first and the last beyond it).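

In this assay the fluoro on an aromatic carbon, meta to a large group, gives a 1.9-fold higher number from compound 2 to compound 3 (0.28 log units; within the scatter) and so stays within the scatter, which means this single change cannot be separated from no change at all. Among these compounds, the larger comparison reads differently: 3-fluorophenyl in place of hydrogen gives a 2.4-fold higher number from compound 1 to compound 3 (0.38 log units; beyond the scatter) and is the first step in this short series to lie beyond the scatter, though only modestly, while phenyl in place of hydrogen gave a 1.3-fold higher number from compound 1 to compound 2 (0.10 log units; within the scatter) and did not leave it. Two steps that each stay within the scatter thus add up to a modest difference across the series, and no measurement at hand bears on why the numbers fall this way.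

On these data alone, it remains open whether this modest difference belongs to the fluoro itself or would appear with any group on this ring, such as a chloro, a methoxy or an amine in the same place. As far as these compounds go, it is also open whether a fluoro elsewhere on the six-membered aromatic ring would read the same, and a single series of three compounds in one cell assay cannot settle either question.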